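This account rests on a few compounds, and the source may have more. Where it says the series, first, only, none or still open, it means among the compounds named here.

The measured compounds and their values in a physicochemical assay for solubility, in phosphate buffer, measured as kinetic solubility, with a stated time of 1 h, at pH 7.4; a higher number here means a more soluble compound, a lower number a less soluble compound:

compound 1, `Cc1cc(C)cc(NC(=O)COc2cc(C)nc3ccccc23)c1`, gives 55000 nM
compound 2, `COc1ccc2nc(C)c(NC(=O)C(=O)Nc3cc(C)cc(C)c3)c(O)c2c1`, gives 10000 nM
compound 3, `COc1ccc2nc(C)cc(OCC(=O)Nc3cc(C)ccc3C)c2c1`, gives 45500 nM

Compound 3 stands second highest of the three numbers. Its nearest neighbour is compound 1, whose number is higher by a gap that lies within the usual scatter of repeated measurements, so the two cannot be told apart on these data. Compound 2 lies furthest away, with a lower number, and that gap is beyond the scatter.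

Compound 4, `COc1ccc2nc(C)cc(OCC(=O)Nc3noc(C)c3C)c2c1`, has not been measured yet. It differs from compound 3 in one place: 4,5-dimethyl-1,2-oxazol-3-yl in place of 2,5-dimethylphenyl on an amide-type nitrogen. For the measured compounds named here, no directly comparable pair among the measured compounds shows what such a change does to solubility, so the expectation rests on the change alone. The step from compound 3 to compound 4 in this assay is expected to be small, a 1.5-fold higher number from compound 3 to compound 4 (0.19 log units; within the scatter), most likely upward but possibly no larger than the scatter. Compound 4 is therefore estimated at 70000 nM, with a likely range from 30000 nM to 160000 nM.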

Compound 4, solubility: 196000 nM
The estimate for compound 4 lay 2.8-fold (0.45 log units) below the measured number, outside the stated range (above it).
By their numbers in this assay, from the lowest: compound 2; then compounds 3 and 1 (each within the scatter of the next); then compound 4.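

In this assay the group on the amide-type nitrogen proves able to shift the number well past the noise: 4,5-dimethyl-1,2-oxazol-3-yl in place of 2,5-dimethylphenyl goes with a 4.3-fold higher number from compound 3 to compound 4 (0.63 log units; beyond the scatter) on an otherwise unchanged structure. The entering group has a five-membered aromatic ring with 2 hetero atoms and 2 hydrogen-bond acceptors, while the leaving group has a six-membered ring of carbon only and no acceptors. Nothing shown here gives a measured reason for this step.

A single pair cannot show whether the ring hetero atoms or the methyl groups on the ring matter more, or whether the same change would give a similar step on the core of compound 1. As far as these compounds go, how an amine or a carboxylic acid on this part of the molecule would compare also remains open.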